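Swapping Nitro for Methoxy on the Benzyl Ether

The source may hold more compounds than are shown below. What is called first, only, known or untested is meant among the compounds shown, and "the series" means these compounds.

Three compounds sharing one core were tested in an ADME assay on Huh-5-2 cells (Homo sapiens) for cytotoxicity, read by WST assay, with a stated time of 3 days; on this read-out higher numbers stand for lower toxicity in this test and lower numbers for higher toxicity in this test. Compound 1 `O=c1c(O)c(-c2ccccc2)oc2cc(OCc3ccccc3Br)cc(O)c12` reaches only the limit of the test, giving > 100000 nM. Compound 2 `O=c1c(O)c(-c2ccccc2)oc2cc(OCc3cccc(Cl)c3)cc(O)c12` likewise reaches only the limit, giving > 100000 nM. Going by the values given here, compound 3 `O=c1c(O)c(-c2ccccc2)oc2cc(OCc3cccc([N+](=O)[O-])c3)cc(O)c12` is the only one with a number, giving 76000 nM in this assay, so it stands as the single readable point, while the other two values sit at the limit of > 100000 nM in this assay, at which 2 of the 3 values shown sit. The measured steps run an at least 1.3-fold lower number from compound 1 to compound 3 (0.11 log units; that floor lies within the scatter) and an at least 1.3-fold lower number from compound 2 to compound 3 (0.11 log units; that floor lies within the scatter), whereas a step that the two limits leave unreadable from compound 1 to compound 2. Compound 4 `COc1cccc(COc2cc(O)c3c(=O)c(O)c(-c4ccccc4)oc3c2)c1` differs from compound 3 by methoxy in place of nitro on an aromatic carbon. Among the compounds with values here, no measured step swaps nitro for methoxy; the nearest comparison is the chloro-to-nitro step, whose floor lies within the scatter. A change of a 1.3-fold higher number from compound 3 to compound 4 (0.10 log units; within the scatter) is therefore expected for compound 4, very possibly ending again at the limit of this assay. The estimate for compound 4 is 95000 nM, expected to fall between 50000 nM and 150000 nM.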

Compound 4, half-maximal cytotoxic concentration: > 100000 nM
Compound 4 ended at the assay's limit (the forecaster's own chance of this, stated with the estimate: 60%); middle value at least 1.0-fold (0.02 log units) from the limit.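

In this assay, methoxy in place of nitro on this aromatic carbon gives an at least 1.3-fold higher number from compound 3 to compound 4 (0.11 log units; that floor lies within the scatter), so this change cannot be said to alter the read-out. The value of compound 4 is a limit of the assay rather than a number, and the steps to compound 4 from compound 1 and from compound 2 cannot be read, since both ends of each are limits. Methoxy now joins chloro at this position in reaching that limit, with compound 3 the one exception, so nearly the whole set rests on a single ceiling: the limit of > 100000 nM in this assay, at which 3 of the 4 values shown sit.

As far as these compounds go, the true values behind these limits stay open, and with them any ranking of chloro, nitro and methoxy in this assay. From the compounds shown here alone, how an amine or a carboxylic acid on this same aromatic carbon would read is also open.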